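This account rests on a few compounds, and the source may have more. Where it says the series, first, only, none or still open, it means among the compounds named here.

Measured compounds:
compound 1 `CC1CCN(c2c(S(=O)(=O)c3ccc(Cl)c(Cl)c3)cnc3cc(F)ccc23)CC1`: 94%
compound 2 `CC1CCN(c2c(S(=O)(=O)c3ccc(F)c(Cl)c3)cnc3cc(F)ccc23)CC1`: 94%
compound 3 `CC1CCN(c2c(S(=O)(=O)c3ccc(F)cc3)cnc3cc(F)ccc23)CC1`: 74.5%

In an assay on isolated protein for displacement of a labelled ligand from metabotropic glutamate receptor 5 (Homo sapiens), with a stated time of 60 min, tested at 1 uM (a lower number here means less inhibition, a higher number more inhibition at the concentration tested (going by the name of the read-out)), compound 1 and compound 2 give numbers that lie within the scatter of each other; the step of no change at the digits printed from compound 2 to compound 1 (within the scatter) is chloro in place of fluoro on an aromatic carbon. Compound 3 gives the lowest number of the three; the step of a number 19.5 percentage points lower from compound 2 to compound 3 (beyond the scatter) is hydrogen in place of chloro on an aromatic carbon, and the step of a number 19.5 percentage points lower from compound 1 to compound 3 (beyond the scatter) points the same way.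

Compound 4 `CC1CCN(c2c(S(=O)(=O)c3ccc(F)cc3)cnc3cc(Cl)ccc23)CC1` has not been measured. It differs from compound 3 by chloro in place of fluoro on an aromatic carbon. Among the measured compounds shown here, this is the same kind of change as the one from compound 2 to compound 1, not the same: in the measured pair the place is ortho to a chloro group and para to a large group, whereas in the new pair it is part of a fused or bridged system of two rings, meta to a fused ring and para to a fused ring. The two cores differ by hydrogen in place of chloro on an aromatic carbon.

The step of a number 3.5 percentage points higher from compound 3 to compound 4 (within the scatter) is expected to be small, resting on compound 2 and the step of no change at the digits printed from compound 2 to compound 1 (within the scatter), which stayed within the scatter. Compound 4 is therefore estimated at 78%, between 62% and 92%.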

Compound 4, a percentage reported as inhibition, at one concentration (the size of the read-out at that concentration, not a potency): 91%
For compound 4 the middle estimate is 13 percentage points below the measured one; measured number inside the range.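

In this assay, chloro in place of fluoro on the aromatic carbon of the fused system, meta to a fused ring and para to a fused ring, gives a number 16.5 percentage points higher from compound 3 to compound 4 (beyond the scatter). The exchange therefore does not carry over at the same size from one core to the other: the same change on two cores in this assay, no change at the digits printed (within the scatter) from compound 2 to compound 1 and a number 16.5 percentage points higher (beyond the scatter) from compound 3 to compound 4, 16.5 percentage points apart, beyond the scatter of two such steps This pair of steps does not show whether the core or the place of the exchange sets the difference, since the two exchanges differ in both, and each step is read at a single concentration, so neither gives a change in potency.

Open, as far as these compounds go, is whether a bromo group or a nitrile on that same aromatic carbon would follow chloro or fluoro. Also open, from the compounds shown here alone, is whether the step from fluoro to chloro on that carbon would persist with 3,4-dichlorophenyl or another aryl group on the sulfonyl sulfur in place of 4-fluorophenyl.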